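Swapping trifluoromethyl for trifluoromethoxy in two related cores

The source may hold more compounds than are shown below. What is called first, only, known or untested is meant among the compounds shown, and "the series" means these compounds.

Of the compounds shown here, three have so far been measured in a functional assay on CWR22R cells (Homo sapiens) for antiproliferative activity, read by propidium iodide staining, with a stated time of 96 h; on this read-out lower numbers stand for stronger inhibition and higher numbers for weaker inhibition. Compound 1 `CC(O)(CSc1ccc(C(F)(F)F)cc1)C(=O)Nc1ccc(S(F)(F)(F)(F)F)cc1` gives 14800 nM. Compound 2 `CC(O)(CSc1ccc(OC(F)(F)F)cc1)C(=O)Nc1ccc(S(F)(F)(F)(F)F)cc1` gives 14900 nM. Compound 3 `CC(O)(CSc1cccc(C(F)(F)F)c1)C(=O)Nc1cccc(S(F)(F)(F)(F)F)c1` gives 12900 nM. All three numbers lie close together. Compound 4 `CC(O)(CSc1cccc(OC(F)(F)F)c1)C(=O)Nc1cccc(S(F)(F)(F)(F)F)c1` has not yet been measured in this assay.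

Compound 2 differs from compound 1 in one place: trifluoromethoxy in place of trifluoromethyl on an aromatic carbon. This change made a 1.0-fold higher number from compound 1 to compound 2 (0.00 log units; within the scatter), so the number hardly moved. Compound 4 differs from compound 3 in one place as well: trifluoromethoxy in place of trifluoromethyl on an aromatic carbon. The two changes are the same kind of change, yet the surroundings of the place are not identical: in the first pair the group sits para to a large group, in the second pair meta to a large group. Compound 3 is built from the same atoms as compound 1, joined differently; the difference between the two cores is not broken down here.

What to expect of compound 4 rests on one measured case. Because the earlier change made a 1.0-fold higher number from compound 1 to compound 2 (0.00 log units; within the scatter), the same kind of change in the second core is expected to leave the number close to where it stands. In this assay the expected step is a 1.0-fold higher number from compound 3 to compound 4 (0.00 log units; within the scatter), though a single precedent in a different core gives only modest confidence. Compound 4 is therefore estimated at 13000 nM, with a plausible range from 6500 nM to 26000 nM.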

Compound 4, half-maximal inhibitory concentration: 18700 nM
For compound 4 the middle estimate is 1.4-fold (0.16 log units) below the measured one; the measured number falls inside the stated range.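

In this assay, putting trifluoromethoxy in place of trifluoromethyl on the core of compound 3 gives a 1.4-fold higher number from compound 3 to compound 4 (0.16 log units; within the scatter). Set beside the same change on the core of compound 1, the new step does not stand apart from the earlier one: the same change on two cores in this assay, a 1.0-fold higher number (0.00 log units; within the scatter) from compound 1 to compound 2 and a 1.4-fold higher number (0.16 log units; within the scatter) from compound 3 to compound 4, 1.4-fold (0.16 log units) apart, within the scatter of two such steps. This shows that, for these two pairs, the change carried from one core to the other with no difference that can be told from the ordinary scatter of the measurement, but two pairs in a single cell assay are too few to make a rule for the series, and they do not show what would happen on any further core or say why the numbers behave as they do.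

The compounds shown leave open how the number would respond if the group on the sulfur-linked ring were something other than trifluoromethyl or trifluoromethoxy, such as a nitrile, a chlorine atom or an amine. They also leave open what a different link in the chain would do, for example an oxygen atom or a sulfonyl group in place of the sulfur atom.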